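Methyl in Place of Trifluoromethyl on the Shared Core

A few compounds are considered here, and "the series" means these few. Any claim that something is new, unique, unknown or untested is made for them only; others in the source may bear on it.

For the measured compounds named here, compound 2 `FC(F)(F)c1ccc(Nc2cncc(N3CC4CC(C3)N4)c2)cc1` gives 0.373 nM in an assay on cell membranes for displacement of a labelled ligand from Neuronal acetylcholine receptor; alpha4/beta2 (Rattus norvegicus) (a lower number here means a stronger inhibitor, a higher number a weaker inhibitor), and has the highest of the two numbers so far; the nearest, compound 1 `O=[N+]([O-])c1ccc(Nc2cncc(N3CC4CC(C3)N4)c2)cc1`, gives 0.0225 nM in this assay, and the step of a 17-fold higher number from compound 1 to compound 2 (1.22 log units; beyond the scatter) is large. Compound 3 `Cc1ccc(Nc2cncc(N3CC4CC(C3)N4)c2)cc1` differs from compound 2 by methyl in place of trifluoromethyl on an aromatic carbon. Going by the values given here, no measured step bears on this exchange directly, so the size of the step is uncertain. Compound 3 is therefore expected to stay close to compound 2, with an estimated step of a 2.1-fold higher number from compound 2 to compound 3 (0.33 log units; beyond the scatter). Compound 3 is estimated to give 0.8 nM, within a range from 0.15 nM to 4 nM.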

Compound 3, inhibition constant: 0.148 nM
For compound 3 the middle estimate is 5.4-fold (0.73 log units) above the measured one; measured number below the stated range.
By their numbers in this assay, from the lowest: compound 1; then compound 3; then compound 2.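

At this aromatic carbon, para to a large group, methyl gives a 2.5-fold lower number from compound 2 to compound 3 (0.40 log units; beyond the scatter) in this assay and so improves on trifluoromethyl, though only modestly. Nitro keeps the lowest number of the three, with a 6.6-fold higher number from compound 1 to compound 3 (0.82 log units; beyond the scatter) for methyl, so the order runs nitro, methyl, trifluoromethyl, and the two groups that replace nitro both fall short of it. No measurement in hand accounts for this order. Still open, on these data alone, is whether an amine, a nitrile or a methoxy group at this carbon would come closer to nitro. As far as these compounds go, a group at another carbon of this ring also remains untested by these compounds.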